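The source may report more compounds than this note shows. Statements on the series, on what has been measured and on what is new or still open speak of the compounds shown alone.

Measured compounds:
Compound 1, `Cc1nc2c3ccccc3ccc2c2nc3c(ccc4ccccc43)c(C)c12`, gives 89.6 ug/mL in a functional assay, read by spectrophotometry, with a stated time of 15 min; a higher number here means a weaker inhibitor, a lower number a stronger inhibitor.
Compound 2, `Cc1nc2c3ccccc3ccc2c2nc3c(ccc4ccccc43)c(-c3ccccc3)c12`, gives 84.6 ug/mL.
Compound 3, `Cc1nc2c3ccccc3ccc2c2nc3c(ccc4ccccc43)c(-c3nccnc3N)c12`, gives 47.8 ug/mL.

Compound 3 gives the smallest of the three numbers, but a 1.9-fold lower number from compound 1 to compound 3 (0.27 log units; within the scatter) and a 1.8-fold lower number from compound 2 to compound 3 (0.25 log units; within the scatter), so on these data the three compounds cannot be told apart. Compound 4, `COc1ccc(-c2c3ccc4ccccc4c3nc3c2c(C)nc2c4ccccc4ccc32)cc1`, differs from compound 3 in one place: 4-methoxyphenyl in place of 3-aminopyrazin-2-yl on an aromatic carbon. Within the data shown here, the steps that bear on this change are the ones made on the same aromatic carbon of the shared core: a 1.1-fold lower number from compound 1 to compound 2 (0.02 log units; within the scatter), a 1.9-fold lower number from compound 1 to compound 3 (0.27 log units; within the scatter) and a 1.8-fold lower number from compound 2 to compound 3 (0.25 log units; within the scatter). Among the measured compounds shown here, every group tried at this position so far has left the number within the scatter, and the 4-methoxyphenyl group that enters is the closest in make-up to the phenyl of compound 2. The expectation for compound 4 is therefore a step of a 1.5-fold higher number from compound 3 to compound 4 (0.17 log units; within the scatter), drifting back toward the value of compound 2, but no step beyond the scatter. Compound 4 is estimated at 70 ug/mL, with a range from 35 ug/mL to 140 ug/mL.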

Compound 4, half-maximal inhibitory concentration: 82.3 ug/mL
The estimate for compound 4 lay 1.2-fold (0.07 log units) below the measured number; measured number inside the range.
By their numbers in this assay, from the lowest: compounds 3, 4, 2 and 1 (each within the scatter of the next).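

In this assay, a carbon-only ring bearing a methoxy group replaces a nitrogen-containing ring with a hydrogen-bond donor, and the result is a 1.7-fold higher number from compound 3 to compound 4 (0.24 log units; within the scatter) even so. Adding the methoxy to the phenyl of compound 2 gives a 1.0-fold lower number from compound 2 to compound 4 (0.01 log units; within the scatter) and the full swap from methyl gives a 1.1-fold lower number from compound 1 to compound 4 (0.04 log units; within the scatter) so four different groups on this aromatic carbon of the shared core now cannot be told apart. Nothing on hand explains why the number stays so flat across these changes.

The groups shown at this position are a methyl and aromatic rings, so the effect of an amine, a carboxylic acid or a longer alkyl chain on this carbon remains open. Whether any group placed here can move the number beyond the scatter also remains unanswered.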